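Capping a phenol: compound 1 to compound 3

The source may hold more compounds than are shown below. What is called first, only, known or untested is meant among the compounds shown, and "the series" means these compounds.

Going by the values given here, compound 1 `O=C(Nc1cccc(-n2cc(-c3ccncc3)c(-c3cc(O)cc(Cl)c3)n2)c1)Nc1ccc(Cl)c(C(F)(F)F)c1` is one of two compounds measured in a functional assay on Malme-3M cells (Homo sapiens) for inhibition, read by sulforhodamine B assay, with a stated time of 48 h, tested at 0.01 uM (on this read-out higher numbers stand for a weaker effect at the one concentration tested and lower numbers for a stronger effect), where compound 1 gives 93%. That is the highest of the two numbers, so compound 1 shows the weaker effect of the pair at the single concentration tested. Among the compounds with values here, its only measured neighbour is compound 2 `O=C(Nc1cccc(-n2cc(-c3ccncc3)c(-c3cc(O)cc(Cl)c3)n2)c1)Nc1ccc(Cl)c(Cl)c1`, which in this assay gives 57%; the step of a number 36 percentage points lower from compound 1 to compound 2 (beyond the scatter) comes from swapping chloro for trifluoromethyl on an aromatic carbon of the urea-bearing ring.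

Compound 3 `COc1cc(Cl)cc(-c2nn(-c3cccc(NC(=O)Nc4ccc(Cl)c(C(F)(F)F)c4)c3)cc2-c2ccncc2)c1` differs from compound 1 at a different place altogether: methyl in place of hydrogen on an oxygen on an aromatic ring. Within the data shown here, no measured step touches that oxygen, so the one recorded change, a number 36 percentage points lower from compound 1 to compound 2 (beyond the scatter), does not speak to what a methyl on the hydroxy should do. With nothing to lean on beyond compound 1 itself, the expected change a number 3 percentage points lower from compound 1 to compound 3 (within the scatter) is none beyond the scatter. Compound 3 is therefore estimated to give 90% in this assay, expected to fall between 72% and 102%.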

Compound 3, a percentage reported as activity, at one concentration (the size of the read-out at that concentration, not a potency): 94%
Estimate against measurement, compound 3: 4 percentage points below; the range from low to high includes it.
By their numbers in this assay, from the lowest: compound 2; then compounds 1 and 3 (each within the scatter of the next).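

Placing a methyl on the oxygen, the change from hydroxy to methoxy, gives a number 1 percentage points higher from compound 1 to compound 3 (within the scatter) in this assay and so leaves compound 3 not separable from compound 1 on this read-out. Going by these compounds alone, this is the first reading at this position, as the earlier step concerned only the group on the urea-bearing ring, and it shows that the hydrogen on this oxygen can be exchanged for a methyl with no difference beyond the scatter at the single concentration tested. The reading is one concentration on compounds that both sit at the weak-effect end of the scale, and no further measurement here explains why the two read alike.

The compounds shown leave open whether a longer chain on this oxygen, such as ethyl, or an amine or a carboxylic acid in place of the hydroxy, would read any differently. They also leave open whether the same methyl would change nothing on compound 2, which gives 57% and so offers more room to see a weaker effect on this scale.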